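The source may hold more compounds than are shown below. What is called first, only, known or untested is meant among the compounds shown, and "the series" means these compounds.

Measured compounds:
- compound 1 `COc1cccc(NC2=CC(=O)c3nc4n(c3C2=O)[C@H]2OC[C@@H](O)[C@H]2OC4)c1` — 4280 nM
- compound 2 `COc1ccccc1NC1=CC(=O)c2c(nc3n2[C@H]2OC[C@@H](O)[C@H]2OC3)C1=O` — 7460 nM
- compound 3 `CCOc1ccccc1NC1=CC(=O)c2nc3n(c2C1=O)[C@H]1OC[C@@H](O)[C@H]1OC3` — 6040 nM

All three share one core and differ only in the aromatic group carried on the amine nitrogen. In a functional assay on HeLa cells (Homo sapiens) for inhibition, read by sulforhodamine B assay (on this read-out lower numbers stand for stronger inhibition and higher numbers for weaker inhibition), compound 1 gives 4280 nM, compound 3 gives 6040 nM, and compound 2 gives 7460 nM. The number for compound 2 is the highest of the three, but its gaps to compound 3 and to compound 1 are both within the usual scatter, so the three compounds cannot be told apart on these data. Among the compounds with values here, the one single-point step available, a 1.4-fold higher number from compound 1 to compound 3 (0.15 log units; within the scatter), confirms that swapping one alkoxyphenyl for another left the read-out essentially unchanged.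

Compound 4 `O=C1C(Nc2ccc(Br)cc2)=CC(=O)c2c1nc1n2[C@H]2OC[C@@H](O)[C@H]2OC1` has not yet been measured in this assay. It differs from compound 2 as follows: 4-bromophenyl in place of 2-methoxyphenyl on an amine nitrogen. Within the data shown here, no measured pair shows a bromophenyl entering or a methoxyphenyl leaving, so nothing bears directly on this step; the only evidence is that the changes seen so far stayed within the scatter. On that basis a step within the scatter is expected, with no clear direction, a 1.4-fold lower number from compound 2 to compound 4 (0.13 log units; within the scatter). The estimate for compound 4 is therefore 5500 nM, with a range from 2000 nM to 15000 nM.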

Compound 4, half-maximal inhibitory concentration: 5220 nM
Estimate against measurement, compound 4: 1.1-fold (0.02 log units) above, within the range that was stated.
By their numbers in this assay, from the lowest: compounds 1, 4, 3 and 2 (each within the scatter of the next).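

Within this assay, replacing 2-methoxyphenyl with 4-bromophenyl on the amine nitrogen gives a 1.4-fold lower number from compound 2 to compound 4 (0.16 log units; within the scatter), so the read-out does not separate these two groups. Until now, every aromatic group shown carried an alkoxy substituent, whereas the 4-bromophenyl of compound 4 has bromine instead and no hydrogen-bond acceptor, so a number in the same range as the others does not depend on an alkoxy oxygen at this position. No measurement among the data shown explains why the two groups read alike.

This step changes the substituent and its place on the ring together, so the contribution of each cannot be separated, and all the compounds shown still carry a substituted phenyl on the amine nitrogen. As far as these compounds go, it remains open whether a carboxylic acid or an amine on that phenyl, or a simple alkyl chain in place of the ring, would give a number clearly beyond the scatter.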